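Bromo in place of chloro: a small step expected

A few compounds are considered here, and "the series" means these few. Any claim that something is new, unique, unknown or untested is made for them only; others in the source may bear on it.

Compound 1 `Nc1ccn(C2OC(CO)C(Br)C2O)c(=O)n1` reaches only the limit > 100 ug/mL in a functional assay on L5178Y cells (Mus musculus) for antiproliferative activity; on this read-out lower numbers stand for stronger inhibition and higher numbers for weaker inhibition.
Compound 2 `Nc1nc(=O)n(C2OC(CO)C(Cl)C2O)cc1F` gives 71 ug/mL in this assay.

For the measured compounds named here, compound 2 stands as the only number in this assay; the other value is a limit, (the limit of > 100 ug/mL in this assay, at which 1 of the 2 values shown sits). Compound 3 `Nc1nc(=O)n(C2OC(CO)C(Br)C2O)cc1F` differs from compound 2 by bromo in place of chloro on a saturated ring carbon. Going by the values given here, no measured pair shows a change of this kind, so the step is expected to stay within the usual scatter, with a step of a 1.2-fold higher number from compound 2 to compound 3 (0.08 log units; within the scatter) expected in this assay. Compound 3 is estimated at 85 ug/mL, with a range from 40 ug/mL to 200 ug/mL.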

Compound 3, concentration for 50% inhibition: 2.6 ug/mL
Compound 3: the middle estimate sits 33-fold (1.51 log units) above what was measured; the whole stated range lies above it.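

For the compounds shown here, on this saturated ring carbon, the choice of halogen can matter far more than the earlier compounds could show: in this assay, bromo in place of chloro gives a 27-fold lower number from compound 2 to compound 3 (1.44 log units; beyond the scatter). With bromo held in place, fluoro in place of hydrogen on an aromatic carbon also counts, giving an at least 38-fold lower number from compound 1 to compound 3 (1.58 log units; beyond the scatter). The value of compound 1 is a limit: the limit of > 100 ug/mL in this assay, at which 1 of the 3 values shown sits.

The compounds shown leave open how iodo or an amine on this ring carbon would compare with bromo. They also leave open whether fluoro in place of hydrogen would count as much with chloro on the ring.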